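The compounds below may be only part of what the source reports. "The series", "measured", "known", "first", "only" and "open" are said of these compounds alone.

Measured so far in a functional assay on the whole organism for inhibition, with Rattus norvegicus as the target; a lower number here means that less compound is needed, a higher number that more compound is needed for the effect:
- compound 1, `CCOC(=O)c1cnc2n(c1=O)C(C)CC/C2=N\Nc1ccc(C(=O)O)cc1`: 100 umol/kg
- compound 2, `CC1CC/C(=N\Nc2ccccc2)c2ncc(CC(=O)O)c(=O)n21`: 100 umol/kg
- compound 3, `CC1CC/C(=N\Nc2ccc(F)cc2)c2ncc(C(=O)O)c(=O)n21`: 12.2 umol/kg

Compound 3 holds the lowest number of the three, and both compound 1 and compound 2 sit beyond the scatter above it, so compound 3 is the most potent compound seen here. Compound 4, `CC1CC/C(=N\Nc2ccccc2O)c2ncc(C(=O)O)c(=O)n21`, is not yet measured. It differs from compound 3 in one place: 2-hydroxyphenyl in place of 4-fluorophenyl on an amine nitrogen. Among the measured compounds shown here, no measured pair shows this kind of change, so the size of the step is open. The expectation is a modest move toward a higher number, possibly no larger than the scatter, as a 2.0-fold higher number from compound 3 to compound 4 (0.31 log units; beyond the scatter). On that basis compound 4 is estimated at 25 umol/kg, with a range from 8 umol/kg to 80 umol/kg.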

Compound 4, dose for 50% inhibition: 0.26 umol/kg
Estimate against measurement, compound 4: 96-fold (1.98 log units) above, and the stated range ends above it.
By their numbers in this assay, from the lowest: compound 4; then compound 3; then compounds 1 and 2 (each within the scatter of the next).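

In this assay, among the compounds shown here, the change from 4-fluorophenyl to 2-hydroxyphenyl on the amine nitrogen gives a 47-fold lower number from compound 3 to compound 4 (1.67 log units; beyond the scatter) and is the first step read. This position can therefore carry a large shift in dose while the rest of the structure stays fixed. Nothing at hand accounts for the size of this step.

On these data alone, it remains open whether the step depends on the hydroxyl itself or on where it sits on the ring. Comparison with 2-methoxyphenyl, 2-aminophenyl or 4-hydroxyphenyl at this position would separate these readings.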